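A Methylpyrazole Amide in Place of the Furan

The compounds below may be only part of what the source reports. "The series", "measured", "known", "first", "only" and "open" are said of these compounds alone.

In a functional assay on DMS-114 cells (Homo sapiens) for inhibition, read by colorimetric assay and sulforhodamine B assay, with a stated time of 48 h (a higher number here means a weaker inhibitor of growth, a lower number a stronger inhibitor of growth), compound 1 `CCCCCCCCCCCC[C@@H](O)[C@H]1CC[C@H]([C@H](O)CCCCCCCCCCNC(=O)c2cccs2)O1` gives 282 nM as the thiophen-2-yl amide. Compound 2 `CCCCCCCCCCCC[C@@H](O)[C@H]1CC[C@H]([C@H](O)CCCCCCCCCCNC(=O)c2ccco2)O1` gives 282 nM as the furan-2-yl amide, and compound 3 `CCCCCCCCCCCC[C@@H](O)[C@H]1CC[C@H]([C@H](O)CCCCCCCCCCNC(=O)c2ccsc2)O1` gives 170 nM as the thiophen-3-yl amide. Compound 2 stands level with compound 1, and all three sit within the scatter of one another.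

Compound 4 `CCCCCCCCCCCC[C@@H](O)[C@H]1CC[C@H]([C@H](O)CCCCCCCCCCNC(=O)c2ccnn2C)O1` carries 1-methyl-1H-pyrazol-5-yl in place of furan-2-yl on a carbonyl carbon, and the change reads 1-methyl-1H-pyrazol-5-yl in place of furan-2-yl on a carbonyl carbon in full. Three measured steps exchange the group at that same place. They are no change at the digits printed from compound 1 to compound 2 (within the scatter) and a 1.7-fold lower number from compound 1 to compound 3 (0.22 log units; within the scatter) and a 1.7-fold lower number from compound 2 to compound 3 (0.22 log units; within the scatter) in turn, each within the scatter. None of them brings in a pyrazolyl group, so they guide the expectation only loosely and the range is kept wide. No step beyond the scatter is therefore expected in this assay for this change. The expected step is a 1.1-fold higher number from compound 2 to compound 4 (0.05 log units; within the scatter) and lies within the scatter. The estimate for compound 4 is 320 nM with an expected range from 130 nM to 800 nM in this read-out.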

Compound 4, concentration for 50% growth inhibition: 10 nM
Compound 4: the middle estimate sits 32-fold (1.51 log units) above what was measured; measured number outside the range, below it.
By their numbers in this assay, from the lowest: compound 4; then compounds 3, 1 and 2 (each within the scatter of the next).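

In this assay, going by these compounds alone, this position on the carbonyl carbon proves far more sensitive than the earlier compounds showed: exchanges among furan-2-yl and the two thiophenyl groups stayed within the scatter, yet 1-methyl-1H-pyrazol-5-yl brings a 28-fold lower number from compound 2 to compound 4 (1.45 log units; beyond the scatter) and a 28-fold lower number from compound 1 to compound 4 (1.45 log units; beyond the scatter) and also a 17-fold lower number from compound 3 to compound 4 (1.23 log units; beyond the scatter) in this series. With all three steps beyond the scatter, compound 4 is the strongest inhibitor of growth of the four. Nothing shown here bears on why the change has this effect.

The compounds shown leave open whether the gain requires the methyl group, as a 1H-pyrazol-5-yl amide would test, or extends to other rings such as 1-methyl-1H-imidazol-5-yl or pyridin-2-yl. They also leave open whether it carries over to cells other than those of this assay.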